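Aromatic oxygen substituent changes in a pyridone series

The source may hold more compounds than are shown below. What is called first, only, known or untested is meant among the compounds shown, and "the series" means these compounds.

Measured in a functional assay on PANC-1 cells (Homo sapiens) for inhibition, read by MTT assay, with a stated time of 24 h, tested at 10 uM; a lower number here means less inhibition, a higher number more inhibition at the concentration tested (going by the name of the read-out):
compound 1 `CC(C)=CCC1Cc2c(OCCCNS(=O)(=O)c3ccc(Br)cc3)cc(=O)n(CCCO)c2CC1(C)C`: 19.5%
compound 2 `CC(C)=CCC1Cc2c(OCCCNC(=O)c3ccc([N+](=O)[O-])cc3)cc(=O)n(CCCO)c2CC1(C)C`: 49.9%
compound 3 `CC(C)=CCC1Cc2c(OCCCOc3ccc(Cl)cc3)cc(=O)n(CCCO)c2CC1(C)C`: 22.7%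

Compound 3 stands second highest of the three, with compound 1 nearest and within the scatter (a number 3.2 percentage points higher from compound 1 to compound 3 (within the scatter)) and compound 2 furthest (a number 27.2 percentage points lower from compound 2 to compound 3 (beyond the scatter)). Compound 4 `CC(C)=CCC1Cc2c(OC(=O)Nc3ccc(F)c(Cl)c3)cc(=O)n(CCCO)c2CC1(C)C` differs from compound 3 in one place: (3-chloro-4-fluorophenyl)carbamoyl in place of 3-(4-chlorophenoxy)propyl on an oxygen on an aromatic ring. Going by the values given here, no measured step alters the oxygen substituent this way; the step of a number 30.4 percentage points higher from compound 1 to compound 2 (beyond the scatter) shows that a carbonyl joined to a nitrogen bearing a hydrogen, which compound 4 also carries, went with a large rise, while a number 27.2 percentage points lower from compound 2 to compound 3 (beyond the scatter) shows the loss of such a group went with a modest fall. For compound 4 a rise is therefore expected, estimated at a number 13.3 percentage points higher from compound 3 to compound 4 (beyond the scatter), giving an expected value of 36% with a range from 16% to 56%.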

Compound 4, a percentage reported as inhibition, at one concentration (the size of the read-out at that concentration, not a potency): 79.8%
Compound 4: middle estimate off by 43.8 percentage points, on the low side; measured number outside the range, above it.
By their numbers in this assay, from the lowest: compounds 1 and 3 (each within the scatter of the next); then compound 2; then compound 4.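

Changing the group on the oxygen on the aromatic ring gives a number 57.1 percentage points higher from compound 3 to compound 4 (beyond the scatter), so in this assay this position responds strongly to the kind of substituent it carries. The entering (3-chloro-4-fluorophenyl)carbamoyl and the leaving 3-(4-chlorophenoxy)propyl have the same heavy-atom count, so the step does not go with a change in group size. No available evidence accounts for this step.

The change replaces the link and the ring halogens together, leaving their separate contributions unresolved. Also open, as far as these compounds go, is how a plain phenyl or a cyclohexyl on the carbamoyl nitrogen would compare.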